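A Smaller Ring in Place of the Lactone Tail

The source may report more compounds than this note shows. Statements on the series, on what has been measured and on what is new or still open speak of the compounds shown alone.

Of the compounds shown here, two have been measured in an assay on microsomes from liver for inhibition of sterol O-acyltransferase 1 (Rattus norvegicus); a higher number here means a weaker inhibitor, a lower number a stronger inhibitor. Compound 1 `COc1ccc(-c2nc(SCC3C[C@](C)(O)CC(=O)O3)[nH]c2-c2ccc(OC)cc2)cc1` gives 420 nM in this assay, while compound 2 `CC1=CC(=O)OC(CSc2nc(-c3ccccc3)c(-c3ccccc3)[nH]2)C1` gives 200 nM, the lower of the two numbers, and the gap between them lies beyond the usual scatter of repeated measurements. Compound 3 `O=C1CCC(CSc2nc(-c3ccccc3)c(-c3ccccc3)[nH]2)N1` has not yet been measured. It differs from compound 2 in one place: a group of 6 heavy atoms (4 carbon, 1 nitrogen, 1 oxygen; one five-membered non-aromatic ring with 1 hetero atom) in place of a group of 8 heavy atoms (6 carbon, 2 oxygen; one six-membered non-aromatic ring with 1 hetero atom), on a saturated chain carbon bound to a sulfur. Among the compounds with values here, no measured pair of compounds shows this change, so its effect on this assay is unknown from the data at hand. For compound 3 the expectation is a small shift toward a weaker inhibitor, of a size that may still fall within the scatter, amounting to a 2.0-fold higher number from compound 2 to compound 3 (0.30 log units; within the scatter). Compound 3 is therefore expected to reach about 400 nM in this assay, with a likely range from 130 nM to 1300 nM.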

Compound 3, half-maximal inhibitory concentration: 360 nM
Beside the measured number, compound 3's estimate is 1.1-fold (0.05 log units) above it; measured number inside the range.
By their numbers in this assay, from the lowest: compounds 2, 3 and 1 (each within the scatter of the next, the first and the last beyond it).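

In this assay, the change on a saturated chain carbon bound to a sulfur, where 5-oxopyrrolidin-2-yl replaces the six-membered ring, gives a 1.8-fold higher number from compound 2 to compound 3 (0.26 log units; within the scatter). Within the data shown here, this is the first sign that the position tolerates a different group: a five-membered ring with a nitrogen and a hydrogen-bond donor, where the earlier group had a six-membered ring and no donor, leaves the number indistinguishable from the scatter. Nothing among the available data speaks to why these two different groups read alike.

From the compounds shown here alone, whether a ring is needed here at all stays open, and a carboxylic acid or a longer chain at this same place would bear on that. Also open, going by these compounds, is whether the amide hydrogen of the 5-oxopyrrolidin-2-yl group matters, which a methyl group on that ring nitrogen would test.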